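Fluorinated phenoxy groups replacing a carbamoylphenoxy terminus

The compounds below may be only part of what the source reports. "The series", "measured", "known", "first", "only" and "open" are said of these compounds alone.

Compound 1, `CC(C)[C@H](NC(=O)COc1cccc2ccccc12)C(=O)N[C@@H](CC(=O)O)C(=O)COc1ccc(C(N)=O)cc1`, gives in a functional assay on Jurkat cells (Homo sapiens) (on this read-out higher numbers stand for weaker inhibition and lower numbers for stronger inhibition), a value of > 100000 nM, which is a limit of the assay and not a number.
Compound 2, `CC(C)[C@H](NC(=O)COc1cccc2ccccc12)C(=O)N[C@@H](CC(=O)O)C(=O)COc1ccc(F)c(F)c1`, gives in this assay a value of > 100000 nM, again a limit.
Compound 3, `CC(C)[C@H](NC(=O)COc1cccc2ccccc12)C(=O)N[C@@H](CC(=O)O)C(=O)COc1ccc(F)c(F)c1F`, gives in this assay a value of 35800 nM.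

Compound 1 therefore stands only at the limit of > 100000 nM in this assay, at which 2 of the 3 values shown sit. Compound 4, `CC(C)[C@H](NC(=O)COc1cccc2ccccc12)C(=O)N[C@@H](CC(=O)O)C(=O)COc1cccc(C(F)(F)F)c1F`, differs from compound 1 by 2-fluoro-3-(trifluoromethyl)phenyl in place of 4-carbamoylphenyl on an oxygen on a saturated carbon. Going by the values given here, two measured steps bear on this change: a step that the two limits leave unreadable from compound 1 to compound 2 and an at least 2.7-fold lower number from compound 1 to compound 3 (0.44 log units; beyond the scatter). The first cannot be read, the second is at least modest toward lower numbers, and an at least 2.7-fold lower number from compound 2 to compound 3 (0.44 log units; beyond the scatter) points the same way. A modest step toward stronger inhibition in this assay is thus expected, though a limit remains possible. Compound 4 is estimated at 40000 nM, between 12000 nM and 130000 nM, which would mean an at least 2.5-fold lower number from compound 1 to compound 4 (0.39 log units; beyond the scatter).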

Compound 4, half-maximal inhibitory concentration: 50400 nM
The estimate for compound 4 lay 1.3-fold (0.10 log units) below the measured number; measured number inside the range.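

With 2-fluoro-3-(trifluoromethyl)phenyl, a second fluorinated phenyl group at this place gives a readable number in this assay, and a 1.4-fold higher number from compound 3 to compound 4 (0.15 log units; within the scatter) leaves it unseparated from 2,3,4-trifluorophenyl. Against the other two groups, the result gives only floors, an at least 1.9-fold lower number from compound 1 to compound 4 (0.29 log units; that floor lies within the scatter) and an at least 1.9-fold lower number from compound 2 to compound 4 (0.29 log units; that floor lies within the scatter), because compounds 1 and 2 each stand at a limit of the assay: the limit of > 100000 nM in this assay, at which 2 of the 4 values shown sit.

The compounds shown leave open whether a single chloro or a nitrile on this phenyl ring would also give a readable number.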